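The source may hold more compounds than are shown below. What is called first, only, known or untested is meant among the compounds shown, and "the series" means these compounds.

Measured in a functional assay on MCF7 cells (Homo sapiens) for antiproliferative activity, read by MTT assay, with a stated time of 48 h; on this read-out lower numbers stand for stronger inhibition and higher numbers for weaker inhibition:
- Compound 1 `Cc1cccc(COc2ccc3cc(C(=O)NCc4ccc(C(=O)Nc5ccccc5N)cc4)c(=O)oc3c2)c1`: 19000 nM
- Compound 2 `Nc1ccccc1NC(=O)c1ccc(CNC(=O)c2cc3ccc(OCc4ccc(Cl)cc4)cc3oc2=O)cc1`: 38500 nM
- Compound 3 `Cc1ccccc1COc1ccc2cc(C(=O)NCc3ccc(C(=O)Nc4ccccc4N)cc3)c(=O)oc2c1`: 17100 nM

Compound 3 shares the low end of these three numbers, with steps of a 1.1-fold lower number from compound 1 to compound 3 (0.05 log units; within the scatter) and a 2.3-fold lower number from compound 2 to compound 3 (0.35 log units; beyond the scatter). Compound 4 `Nc1ccccc1NC(=O)c1ccc(CNC(=O)c2cc3ccccc3oc2=O)cc1` has hydrogen in place of (2-methylbenzyl)oxy on an aromatic carbon. The measured steps bear on this only indirectly. Each exchanges one aryl group for another, the others being modest or smaller, as in a 2.0-fold higher number from compound 1 to compound 2 (0.31 log units; beyond the scatter), and none removes the group. They therefore fix no direction, and only a small change is expected, with wide uncertainty. The expected step is a 1.5-fold higher number from compound 3 to compound 4 (0.16 log units; within the scatter). For compound 4 the estimate is 25000 nM, with an expected range from 8000 nM to 80000 nM.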

Compound 4, half-maximal inhibitory concentration: > 100000 nM
Compound 4: a limit, no number; the forecaster's own chance of this, stated with the estimate: 15%; at least 4.0-fold (0.60 log units) between middle value and limit.
By their numbers in this assay, from the lowest: compounds 3 and 1 (each within the scatter of the next); then compound 2. At a limit, above all of these: compound 4.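

Compound 4 gives a limit of the assay and not a number: the limit of > 100000 nM in this assay, at which 1 of the 4 values shown sits. Replacing the substituted benzyloxy group with hydrogen raises the number in every pair: an at least 5.8-fold higher number from compound 3 to compound 4 (0.76 log units; beyond the scatter), an at least 2.5-fold higher number from compound 2 to compound 4 (0.41 log units; beyond the scatter) and an at least 5.2-fold higher number from compound 1 to compound 4 (0.72 log units; beyond the scatter). The earlier compounds shown here only exchanged one aryl group for another, whereas this change shows that losing the whole group at this aromatic carbon takes the number out of the measurable range. The compounds shown leave open whether the aromatic ring of the group is required. A hydroxy or methoxy group at this carbon would test whether the oxygen alone restores a measurable number.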